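Pyrazole Series at the Prostaglandin Receptor: Compound 3 to 4

A few compounds are considered here, and "the series" means these few. Any claim that something is new, unique, unknown or untested is made for them only; others in the source may bear on it.

Measured so far:
- compound 1 `Cc1cc(C(=O)O)nn1Cc1cc(Br)ccc1OCc1ccccc1`: 6.31 nM
- compound 2 `Cc1cc(C(=O)O)nn1C(C)c1cc(Cl)ccc1OCc1ccccc1`: 10 nM
- compound 3 `Cc1cc(C(=O)NCc2ccccc2)nn1Cc1cc(Cl)ccc1OCc1ccccc1`: 39.8 nM

In an assay on CHO-K1 cells for displacement of a labelled ligand from prostaglandin E2 receptor EP1 subtype (Homo sapiens) (a higher number here means a weaker inhibitor, a lower number a stronger inhibitor), compound 3 gives 39.8 nM and stands highest of the three numbers. Compound 2 gives 10 nM and compound 1 gives 6.31 nM; both of those numbers are beyond the scatter away from compound 3, so compound 3 is the weakest inhibitor of the three on the numbers shown.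

The next compound, compound 4 `Cc1cc(NC(=O)OC(C)(C)C)nn1Cc1cc(Cl)ccc1OCc1ccccc1`, is not yet measured in this assay. It differs from compound 3 in one place: (tert-butoxycarbonyl)amino in place of benzylcarbamoyl on an aromatic carbon.

Within the data shown here, no step between two measured compounds carries a change of this kind, so there is no measured step to lean on. Compound 3 already carries the highest number of the three, and the group that enters for compound 4 is smaller and of a different make-up than the one that leaves. The expectation is a further rise in the number, of modest size, for compound 4 in this assay, beyond the scatter but not large: the expected step from compound 3 to compound 4 is a 2.5-fold higher number from compound 3 to compound 4 (0.40 log units; beyond the scatter).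

The estimate for compound 4 in this assay is 100 nM, with an expected range from 25 nM to 400 nM.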

Compound 4, half-maximal inhibitory concentration: 25.1 nM
For compound 4 the middle estimate is 4.0-fold (0.60 log units) above the measured one; the range from low to high includes it.
By their numbers in this assay, from the lowest: compounds 1 and 2 (each within the scatter of the next); then compounds 4 and 3 (each within the scatter of the next).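

In this assay, placing (tert-butoxycarbonyl)amino instead of benzylcarbamoyl on the aromatic carbon next to the ring nitrogen gives a 1.6-fold lower number from compound 3 to compound 4 (0.20 log units; within the scatter). This is the first step shown at this position, and it indicates that, for this pair, the assay does not separate a group with a six-membered aromatic ring from one with no ring, although one group joins the core through its carbonyl carbon and the other through its nitrogen. No measurement shown accounts for this similarity.

As far as these compounds go, it remains open whether any carbonyl-bearing group is needed here: a plain amine or a primary carboxamide on the core of compound 3 would address this. A carboxylic acid on that same core also remains to be compared, as compounds 1 and 2 each differ from compound 3 in more than one place.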